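The compounds below may be only part of what the source reports. "The series", "measured", "known", "first", "only" and "open" are said of these compounds alone.

Working notes on the series. For the measured compounds named here, in a functional assay on HT-29 cells (Homo sapiens) for inhibition, read by sulforhodamine B assay, with a stated time of 72 h (a lower number here means a stronger inhibitor, a higher number a weaker inhibitor), compound 2 (`CCOc1ccc(C2C(O)C(=O)N2c2cc(OC)c(OC)c(OC)c2)cc1`) gives 15 nM as the lower of the two numbers measured so far. Compound 1 (`C=CC1C(=O)N(c2cc(OC)c(OC)c(OC)c2)C1c1ccc(SC)cc1`) gives 113 nM as the higher number, and the gap between the two lies beyond the scatter. These two compounds differ in more than one place, so their gap cannot be assigned to a single change.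

The next compound is compound 3 (`C=CC1C(=O)N(c2cc(OC)c(OC)c(OC)c2)C1c1ccc(OCC)cc1`). It keeps the 4-ethoxyphenyl group of compound 2 and carries vinyl in place of hydroxy on a saturated ring carbon. Going by the values given here, no measured step isolates this swap. Among the compounds with values here, the only guide is compound 1, which also carries vinyl and gives 113 nM in this assay with a different group in place of the 4-ethoxyphenyl group. A moderate move toward weaker inhibition is therefore expected, with the estimated change (a 2.7-fold higher number from compound 2 to compound 3 (0.43 log units; beyond the scatter)) likely to lie just beyond the scatter. Compound 3 is estimated at 40 nM (expected range 10 nM to 150 nM).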

Compound 3, half-maximal inhibitory concentration: 97 nM
Compound 3: the middle estimate sits 2.4-fold (0.38 log units) below what was measured; the range from low to high includes it.
By their numbers in this assay, from the lowest: compound 2; then compounds 3 and 1 (each within the scatter of the next).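

In this assay the exchange on the saturated ring carbon now has its own measured step with the 4-ethoxyphenyl group held fixed: vinyl in place of hydroxy gives a 6.5-fold higher number from compound 2 to compound 3 (0.81 log units; beyond the scatter) and so leaves hydroxy as the form with the lower number in this pair. With vinyl held fixed, ethoxy in place of methylsulfanyl on an aromatic carbon gives a 1.2-fold lower number from compound 1 to compound 3 (0.07 log units; within the scatter) and thus no readable difference, so of the two steps shown only the one on the saturated ring carbon moves the number beyond the scatter. Hydroxy leaves with its hydrogen-bond donor and acceptor and vinyl enters with neither, and no measurement at hand says what in this exchange accounts for the step.

The compounds shown leave open how an amino group, a methoxy group or an ethyl group on this saturated ring carbon would compare with hydroxy and vinyl. They also leave open whether the step seen with the 4-ethoxyphenyl group holds with methylsulfanyl on the aromatic carbon, and how a longer alkoxy chain there would read.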